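The compounds below may be only part of what the source reports. "The series", "measured", "known", "first", "only" and "open" are said of these compounds alone.

Compound 3 `O=S(=O)(Nc1nccs1)c1ccc2c(c1)OCC[C@@H]2c1ccc(C(F)(F)F)cc1-c1ccc(F)nc1` gives the lowest number of the three in a physicochemical assay for solubility (on this read-out lower numbers stand for lower solubility and higher numbers for higher solubility), 21000 nM; compound 1 `O=S(=O)(Nc1ncccn1)c1ccc2c(c1)OCC[C@@H]2c1ccc(C(F)(F)F)cc1-c1ccc(F)nc1` gives 408000 nM and compound 2 `O=S(=O)(Nc1ncccn1)c1ccc2c(c1)OCC[C@@H]2c1ccc(C(F)(F)F)cc1-c1ccc(F)cn1` gives 225000 nM. Compound 4 `CN1CCN(c2cc(C(F)(F)F)ccc2[C@H]2CCOc3cc(S(=O)(=O)Nc4nccs4)ccc32)CC1` differs from compound 3 in one place: 4-methylpiperazin-1-yl in place of 6-fluoropyridin-3-yl on an aromatic carbon. Neither measured step covers this change directly. The step of a 1.8-fold lower number from compound 1 to compound 2 (0.26 log units; within the scatter) exchanges one aromatic ring for another on an aromatic carbon, while the step of a 19-fold lower number from compound 1 to compound 3 (1.29 log units; beyond the scatter) alters the group on the sulfonamide nitrogen, which compound 4 keeps. For the measured compounds named here, with no close precedent, the analyst expects a moderate rise in this assay, a 2.9-fold higher number from compound 3 to compound 4 (0.46 log units; beyond the scatter), and estimates compound 4 at 60000 nM, with a wide range from 15000 nM to 250000 nM.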

Compound 4, solubility: 176000 nM
For compound 4 the middle estimate is 2.9-fold (0.47 log units) below the measured one, and the stated range covers the measured number.
By their numbers in this assay, from the lowest: compound 3; then compounds 4, 2 and 1 (each within the scatter of the next, the first and the last beyond it).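

Replacing the aromatic 6-fluoropyridin-3-yl with the non-aromatic 4-methylpiperazin-1-yl at this position, ortho to a large group, gives an 8.4-fold higher number from compound 3 to compound 4 (0.92 log units; beyond the scatter) in this assay. The earlier exchange of one aromatic ring for another here, a 1.8-fold lower number from compound 1 to compound 2 (0.26 log units; within the scatter), stayed within the scatter, so this position is not indifferent to what it carries, although the two changes stand on different sulfonamide groups. No evidence bears on the origin of this rise. The compounds shown leave open whether the change holds with pyrimidin-2-yl on the sulfonamide nitrogen. They also leave open whether morpholine or a dimethylamino group here would behave like 4-methylpiperazin-1-yl.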